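The compounds below may be only part of what the source reports. "The series", "measured", "known", "first", "only" and "open" are said of these compounds alone.

Measured so far in a functional assay on NCI-H460 cells (Homo sapiens) for cytotoxicity, read by MTT assay, with a stated time of 48 h; a lower number here means a stronger inhibitor, a higher number a weaker inhibitor:
- compound 1 `C=C1C(=O)O[C@H]2CC3=C[C@H](C/C(C)=C/[C@@H](OC(=O)c4ccc([N+](=O)[O-])cc4)[C@H]12)OC3=O`: > 10000 nM, a limit
- compound 2 `C=C1C(=O)O[C@H]2CC3=C[C@H](C/C(C)=C/[C@@H](OC(=O)/C=C/c4cccc(OC)c4)[C@H]12)OC3=O`: > 10000 nM, a limit
- compound 3 `C=C1C(=O)O[C@H]2CC3=C[C@H](C/C(C)=C/[C@@H](OC(=O)C45CCC(C)(C(=O)O4)C5(C)C)[C@H]12)OC3=O`: 2000 nM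

For the measured compounds named here, compound 3 gives 2000 nM, the only actual number. Compound 1 and compound 2 both stand at the limit of > 10000 nM in this assay, at which 2 of the 3 values shown sit.

The next compound, still unmeasured, is compound 4 `C=C1C(=O)O[C@H]2CC3=C[C@H](C/C(C)=C/[C@@H](OC(=O)C4CC4)[C@H]12)OC3=O`. Its change from compound 3 is a group of 3 heavy atoms (3 carbon; one three-membered non-aromatic ring of carbon only) in place of a group of 11 heavy atoms (9 carbon, 2 oxygen; one five-membered non-aromatic ring of carbon only, one five-membered non-aromatic ring with 1 hetero atom), on a carbonyl carbon. Cyclopropyl thus enters where the larger two-ring group stood.

Two readable steps bear on this, both changes on the same carbonyl carbon. One is an at least 5.0-fold lower number from compound 1 to compound 3 (0.69 log units; beyond the scatter). The other is an at least 5.0-fold lower number from compound 2 to compound 3 (0.69 log units; beyond the scatter). Both are bounds rather than exact sizes, and neither involves cyclopropyl. The step that the two limits leave unreadable from compound 1 to compound 2 adds no size.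

So far, only the two-ring group of compound 3 has given a number, and the two aromatic groups have not. On that narrow basis, a modest rise in the number is expected on leaving this group in this assay, and compound 4 may itself reach the limit. The expected step is a 2.5-fold higher number from compound 3 to compound 4 (0.40 log units; beyond the scatter). For compound 4 the estimate is 5000 nM, with an expected range of 1800 nM to 10000 nM.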

Compound 4, half-maximal inhibitory concentration: 3000 nM
For compound 4 the middle estimate is 1.7-fold (0.22 log units) above the measured one, and the stated range covers the measured number.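

In this assay, the replacement at this carbonyl carbon gives a 1.5-fold higher number from compound 3 to compound 4 (0.18 log units; within the scatter). The large two-ring group is therefore not needed for a measurable number in this small set: cyclopropyl, with 3 heavy atoms and no hydrogen-bond acceptors, stands level with a group of 11 heavy atoms and 2 hydrogen-bond acceptors. Cyclopropyl also separates from both groups carrying an aromatic ring, with an at least 3.3-fold lower number from compound 2 to compound 4 (0.52 log units; beyond the scatter) and an at least 3.3-fold lower number from compound 1 to compound 4 (0.52 log units; beyond the scatter), so across these four compounds the two groups without an aromatic ring give numbers and the 4-nitrophenyl and 2-(3-methoxyphenyl)ethenyl groups give only limits, with no compound going against this.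

Whether that split depends on the aromatic ring itself stays open, as the compounds shown include no open-chain group such as a butyl chain and no group carrying an amine on this carbonyl carbon, and it is also unknown whether any group here can reach a much lower number than the two measured ones. The steps from the two aromatic compounds remain bounds, without an exact size: the limit of > 10000 nM in this assay, at which 2 of the 4 values shown sit.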